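Triazole-linked chalcones: swapping the benzyl halogen

This account rests on a few compounds, and the source may have more. Where it says the series, first, only, none or still open, it means among the compounds named here.

The series rests on one shared core, seen in compound 1 `O=C(/C=C/c1ccc(OCc2cn(Cc3ccccc3Br)nn2)cc1)c1ccc(Br)cc1` and compound 2 `COc1ccc(C(=O)/C=C/c2ccc(OCc3cn(Cc4ccccc4Br)nn3)cc2)cc1`. In a functional assay on MCF7 cells (Homo sapiens) for inhibition, read by MTT assay, with a stated time of 48 h, tested at 10 uM (a lower number here means less inhibition of growth, a higher number more inhibition of growth at the concentration tested), compound 1 gives 44%, while compound 2 gives 60%. Within the data shown here, the only measured step, a number 16 percentage points higher from compound 1 to compound 2 (beyond the scatter), places compound 2 at the top of the two numbers, with compound 1 the nearer and lower of them.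

Compound 3 `COc1ccc(C(=O)/C=C/c2ccc(OCc3cn(Cc4ccc(F)cc4)nn3)cc2)cc1` has not yet been measured. It differs from compound 2 in one place: 4-fluorophenyl in place of 2-bromophenyl on a saturated chain carbon bound to an aromatic nitrogen. Among the measured compounds shown here, this change sits on the benzyl arm attached to the triazole, a region that no measured step in this assay touches; the step from compound 1 to compound 2 altered the aryl ketone end instead, so its size offers no direct guide here.

For the measured compounds named here, with no comparable step to draw on, the estimate for compound 3 is expected to stay close to compound 2, with a step of a number 5 percentage points lower from compound 2 to compound 3 (within the scatter) regarded as most likely. Compound 3 is therefore expected to show about 55% in this assay, within a range from 38% to 72%.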

Compound 3, percent growth inhibition at one concentration: 15%
For compound 3 the middle estimate is 40 percentage points above the measured one; the whole stated range lies above it.
By their numbers in this assay, from the lowest: compound 3; then compound 1; then compound 2.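

In this assay, among these compounds, the benzyl arm proves to be a sensitive position, which the earlier compounds could not show: 4-fluorophenyl in place of 2-bromophenyl on a saturated chain carbon bound to an aromatic nitrogen gives a number 45 percentage points lower from compound 2 to compound 3 (beyond the scatter) and is thus a much larger step than a number 16 percentage points higher from compound 1 to compound 2 (beyond the scatter) on the other side of the molecule. The two groups match in heavy atom count, in their single six-membered aromatic ring, in hydrogen-bond donors and acceptors and in net charge, so these counts do not separate them, while the halogen and its place on the ring change together in this one step, leaving the two contributions inseparable. No available evidence accounts for the size of this drop.

From the compounds shown here alone, it remains open whether the halogen or its place on the ring matters more, and whether the same swap would give a step of similar size with bromo rather than methoxy on the other aromatic ring. Going by these compounds, it is also open how this position would respond to a plain phenyl, or to a phenyl carrying an amine or a carboxylic acid.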